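Hydrogen in Place of Chloro: Compound 1 to Compound 4

A few compounds are considered here, and "the series" means these few. Any claim that something is new, unique, unknown or untested is made for them only; others in the source may bear on it.

Measured in an ADME assay on MT4 cells (Homo sapiens) for cytotoxicity, read by MTT assay, with a stated time of 96 h; on this read-out higher numbers stand for lower toxicity in this test and lower numbers for higher toxicity in this test:
compound 1 `S=C(Nc1ccc(Cl)c(Cl)c1)Nc1nc[nH]n1`: 47000 nM
compound 2 `Cc1ccc(NC(=S)Nc2nc[nH]n2)cc1`: 59000 nM
compound 3 `Nc1ncnn1/C(S)=N/Cc1ccccc1`: 7400 nM

Among these three, compound 1 at 47000 nM lies within the scatter of compound 2, while compound 3 gives a lower number, beyond the scatter of compound 1. The next compound to be tested is compound 4 `S=C(Nc1ccc(Cl)cc1)Nc1nc[nH]n1`, and it departs from compound 1 by one change: hydrogen in place of chloro on an aromatic carbon. Hydrogen thus stands in place of chloro on an aromatic carbon.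

Going by the values given here, no measured pair shows this change on its own, so any expectation rests on indirect evidence. Compound 1 and compound 2 carry different groups on the aromatic ring, yet their values stay within the scatter of each other. Compound 3 is built differently and offers little guidance. A step beyond the scatter is therefore not expected in this assay. The estimated step of a 1.1-fold higher number from compound 1 to compound 4 (0.03 log units; within the scatter) stays within the scatter. For compound 4 the estimated value is 50000 nM, with an expected range from 25000 nM to 100000 nM.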

Compound 4, half-maximal cytotoxic concentration: 47000 nM
Compound 4: the middle estimate sits 1.1-fold (0.03 log units) above what was measured; low and high end bracket the measured number.
By their numbers in this assay, from the lowest: compound 3; then compounds 1, 4 and 2 (each within the scatter of the next).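

In this assay, the change gets its first direct reading, with hydrogen in place of chloro on an aromatic carbon giving no change at the digits printed from compound 1 to compound 4 (within the scatter), so this position, ortho to a chloro group and meta to a group of 9 heavy atoms, tolerates losing its chloro in this test. The second comparison, chloro in place of methyl on an aromatic carbon, gives a 1.3-fold lower number from compound 2 to compound 4 (0.10 log units; within the scatter), so hydrogen, chloro and methyl on this ring all leave the number within the scatter in the pairs read here. Nothing in hand explains why this read-out stays so flat across these pairs.

As far as these compounds go, it remains open whether an amine, a carboxylic acid or a longer chain on the same ring would take the number beyond the scatter. Also open, from the compounds shown here alone, is whether hydrogen in place of the remaining chloro would leave it just as flat.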